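Cyclohexylamino replacement for the trimethoxyanilino group in compound 2

A few compounds are considered here, and "the series" means these few. Any claim that something is new, unique, unknown or untested is made for them only; others in the source may bear on it.

Working notes. In a functional assay on MDA-MB-231 cells (Homo sapiens) for cytotoxicity, read by MTT assay, with a stated time of 72 h (a higher number here means a weaker inhibitor, a lower number a stronger inhibitor), compound 2 `COc1ccc(Cn2nc(-c3ccccc3)c3cc(C(=N)Nc4ccc(N5CCN(C)CC5)cc4)nc(Nc4cc(OC)c(OC)c(OC)c4)c32)cc1` gives 890 nM, the lowest of the three numbers measured; compound 3 `N=C(Nc1ccccc1)c1cc2c(-c3ccccc3)n[nH]c2cn1` gives 11000 nM and compound 1 `Cn1nc(-c2ccccc2)c2cc(C(=N)Nc3ccccc3)ncc21` gives 11100 nM, both beyond the scatter above compound 2. Among the measured compounds shown here, the one measured step, a 1.0-fold lower number from compound 1 to compound 3 (0.00 log units; within the scatter), concerns only the substituent on the ring nitrogen and does not bear on the change considered here. Compound 4 `COc1ccc(Cn2nc(-c3ccccc3)c3cc(C(=N)Nc4ccc(N5CCN(C)CC5)cc4)nc(NC4CCCCC4)c32)cc1` differs from compound 2 by cyclohexyl in place of 3,4,5-trimethoxyphenyl on a nitrogen on an aromatic ring. For the measured compounds named here, no measured pair tests this exchange, so the expectation rests on compound 2 alone, and a step in this assay of a 2.8-fold higher number from compound 2 to compound 4 (0.45 log units; beyond the scatter), toward a higher number, is estimated with wide uncertainty. Compound 4 is therefore expected to give 2500 nM, within 600 nM to 10000 nM.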

Compound 4, half-maximal inhibitory concentration: 129000 nM
For compound 4 the middle estimate is 52-fold (1.71 log units) below the measured one; the measured number lies above the stated range.
By their numbers in this assay, from the lowest: compound 2; then compounds 3 and 1 (each within the scatter of the next); then compound 4.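

In this assay, the position on the nitrogen on an aromatic ring proves highly sensitive: cyclohexyl in place of 3,4,5-trimethoxyphenyl gives a 140-fold higher number from compound 2 to compound 4 (2.16 log units; beyond the scatter). This single exchange changes the ring from aromatic to non-aromatic and also removes the three methoxy groups, so the step cannot assign the loss to either difference. No measurement available here accounts for the size of the step.

Still open, as far as these compounds go, is whether an unsubstituted phenyl on this nitrogen would stay close to compound 2 or fall toward compound 4. A piperidine ring or a short alkyl chain at this position also remains untested in the compounds shown.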